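The source may hold more compounds than are shown below. What is called first, only, known or untested is meant among the compounds shown, and "the series" means these compounds.

In a functional assay on the whole organism (Hindlimb, strain albino) with Mus musculus as the target, in the maximal electroshock model, with a stated time of 0.5 h (a lower number here means that less compound is needed, a higher number that more compound is needed for the effect), compound 1 (`COc1ccc(/C=C/C(=O)Nc2nc3ccccc3s2)cc1O`) gives 495 umol/kg and compound 2 (`COc1ccc(/C=C/C(=O)Nc2nc3ccc(Cl)cc3s2)cc1O`) gives 320 umol/kg, so compound 2 stands within the scatter of compound 1. Compound 3 (`COc1ccc(/C=C/C(=O)Nc2nc3ccc(C)cc3s2)cc1O`) has methyl in place of chloro on an aromatic carbon. Going by the values given here, the only measured step that bears on this (a 1.5-fold lower number from compound 1 to compound 2 (0.19 log units; within the scatter)) put chloro in place of hydrogen on an aromatic carbon and stayed within the scatter, so no step beyond the scatter is expected in this assay here. The expected step is a 1.3-fold higher number from compound 2 to compound 3 (0.10 log units; within the scatter) by this estimate. The estimate for compound 3 is 400 umol/kg with 200 umol/kg to 800 umol/kg as its expected range.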

Compound 3, dose for half-maximal effect: 271 umol/kg
Compound 3: the middle estimate sits 1.5-fold (0.17 log units) above what was measured, within the range that was stated.
By their numbers in this assay, from the lowest: compounds 3, 2 and 1 (each within the scatter of the next).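

Methyl in place of chloro at this position of the shared core gives a 1.2-fold lower number from compound 2 to compound 3 (0.07 log units; within the scatter) in this assay and so adds a second substituent on this aromatic carbon that stays within the scatter. Methyl in place of hydrogen gives a 1.8-fold lower number from compound 1 to compound 3 (0.26 log units; within the scatter) and likewise stays within the scatter, so neither substituent shown here moves the number beyond it. Nothing available explains these readings. The compounds leave open whether an amine, a carboxylic acid or a longer chain on this aromatic carbon would produce a step beyond the scatter.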